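The compounds below may be only part of what the source reports. "The series", "measured", "known", "first", "only" and "open" are said of these compounds alone.

Series notes. Compound 2 `Cc1ccc(S(=O)(=O)NCc2ccc(CNC(=O)c3ccncc3)cc2)cc1` carries a pyridin-4-yl on the carbonyl carbon; in an assay on MDA-MB-231 cells for binding affinity to C-X-C chemokine receptor type 4 (Homo sapiens), read by immunofluorescence and microscopy, with stated times of 10 min and 30 min (a higher number here means that more compound is needed for the effect, a lower number that less compound is needed), compound 2 gives 10 nM. Compound 1 `Cc1ccc(S(=O)(=O)NCc2ccc(CNC(=O)c3ccc(Cl)cc3)cc2)cc1` gives 10 nM, and compound 3 `O=C(NCc1ccc(CNS(=O)(=O)c2ccccc2)cc1)c1ccncc1` gives 10 nM, so compound 2 stands level with both at the digits shown. Compound 4 `Cc1ccc(C(=O)NCc2ccc(CNS(=O)(=O)c3ccc(C)cc3)cc2)cc1` is not yet measured. Its change from compound 2 is 4-methylphenyl in place of pyridin-4-yl on a carbonyl carbon. The step that bears on it is the one at the same carbonyl carbon, no change at the digits printed from compound 1 to compound 2 (within the scatter), where 4-chlorophenyl gave way to pyridin-4-yl; the other step, no change at the digits printed from compound 2 to compound 3 (within the scatter), lies elsewhere and also shows nothing beyond the scatter. Returning to a six-membered ring of carbon only at this carbonyl is therefore expected to give no change at the digits printed from compound 2 to compound 4 (within the scatter), no step beyond the scatter. Compound 4 is thus estimated at 10 nM, with a range of 5 nM to 20 nM.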

Compound 4, effective concentration (reported as EC, without a stated level of effect): 1000 nM
Compound 4: middle estimate off by 100-fold (2.00 log units), on the low side; measured number outside the range, above it.
By their numbers in this assay, from the lowest: compounds 1, 2 and 3 (each within the scatter of the next); then compound 4.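

In this assay the group on the carbonyl carbon proves to matter: 4-methylphenyl in place of pyridin-4-yl gives a 100-fold higher number from compound 2 to compound 4 (2.00 log units; beyond the scatter) and methyl in place of chloro on an aromatic carbon gives a 100-fold higher number from compound 1 to compound 4 (2.00 log units; beyond the scatter) within the same series. The level readings of compounds 1 and 2 therefore did not show a position open to any six-membered aromatic ring, since the exchange of chloro for methyl alone separates compound 4 from compound 1. No supporting measurement bears on why this happens.

Open, going by these compounds, is how unsubstituted phenyl, 4-fluorophenyl or 4-methoxyphenyl would read on this carbonyl. Also open, on these data alone, is whether a 4-aminophenyl or a longer chain in place of the methyl would read like compound 1 or like compound 4.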